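Replacing a cyclic amide substituent with an open chain

The source may report more compounds than this note shows. Statements on the series, on what has been measured and on what is new or still open speak of the compounds shown alone.

Among the measured compounds shown here, compound 2 `COc1ccc(C#Cc2ccc(C(=O)N3CCC(CO)C3)cc2)cc1` is the only member of this small set with a numerical result: in a functional assay on TREX cells for negative allosteric modulation of metabotropic glutamate receptor 3 (Rattus norvegicus), read by calcium flux, with a stated time of 2.5 min (on this read-out higher numbers stand for weaker inhibition and lower numbers for stronger inhibition), compound 2 gives 7590 nM. Compound 1 `COc1ccc(C#Cc2ccc(C(=O)N3CCC[C@@H](CO)C3)cc2)c(F)c1` reaches only a limit of the assay, > 10000 nM. Compound 3 `COc1ccc(C#Cc2ccc(C(=O)N3CCC[C@@H](CO)C3)cc2)cn1` likewise sits at a limit, > 10000 nM. For the measured compounds named here, the single change among the measured compounds, a step that the two limits leave unreadable from compound 1 to compound 3, therefore cannot be read, and the only evidence is the limit of > 10000 nM in this assay, at which 2 of the 3 values shown sit. Compound 4 `COc1ccc(C#Cc2ccc(C(=O)NC(C)CO)cc2)cc1` arises from compound 2 by (1-(hydroxymethyl)ethyl)amino in place of 3-(hydroxymethyl)pyrrolidin-1-yl on a carbonyl carbon. Going by the values given here, no measured step touches the amide side of the shared core, so the data give no size for this change; the account expects no shift beyond the usual scatter, with a real chance that compound 4 also ends at a limit of this assay. Compound 4 is accordingly estimated at 9000 nM in this assay, within a range from 4000 nM to 20000 nM. The expected step is a 1.2-fold higher number from compound 2 to compound 4 (0.07 log units; within the scatter).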

Compound 4, half-maximal inhibitory concentration: 7590 nM
For compound 4 the middle estimate is 1.2-fold (0.07 log units) above the measured one; the measured number falls inside the stated range.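

In this assay, (1-(hydroxymethyl)ethyl)amino in place of 3-(hydroxymethyl)pyrrolidin-1-yl on a carbonyl carbon gives no change at the digits printed from compound 2 to compound 4 (within the scatter). Among the compounds shown here, this is the first step on the amide side of the shared core that can be read, and it shows that, for this pair, losing the five-membered ring leaves the read-out unmoved, even with the amide hydrogen that enters. The pair still offers little room for reading further changes at this end of the assay: the limit of > 10000 nM in this assay, at which 2 of the 4 values shown sit.

On these data alone, whether the hydroxyl of the hydroxymethyl group matters at this position stays open, as does what a carboxylic acid or an amine in its place, or a longer chain on the amide nitrogen, would give. The step between the two limits of compound 1 and compound 3 still cannot be read.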